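The source may report more compounds than this note shows. Statements on the series, on what has been measured and on what is new or still open speak of the compounds shown alone.

Among the three compounds measured in a functional assay on HL-60 cells (Homo sapiens) for inhibition, read by MTT assay, with a stated time of 72 h, tested at 30 uM (on this read-out higher numbers stand for more inhibition of growth at the one concentration tested and lower numbers for less inhibition of growth), compound 1 `C=CCc1cc(O)c(O)c(CN2CCC(C)CC2)c1` stands highest with 91.1%. Compound 3 `C=CCc1ccc(OCc2cn(-c3ccccc3CO)nn2)c(O)c1` follows with 31.7% and compound 2 `C=CCc1ccc(OCc2cn(-c3ccc(C#N)cc3)nn2)c(O)c1` with 20.8%, both well beyond the scatter from compound 1. The next compound, compound 4 `C=CCc1cc(O)c(O)c(CN2CCC(Cc3ccccc3)CC2)c1`, keeps the core of compound 1 but carries phenyl in place of hydrogen on a saturated chain carbon bound to a saturated ring carbon, which turns methyl into benzyl (phenyl in place of hydrogen on a saturated chain carbon bound to a saturated ring carbon). Going by the values given here, the only measured step between close neighbours is modest: a number 10.9 percentage points higher from compound 2 to compound 3 (beyond the scatter). It swaps a different group at a different place on another scaffold, so it bears on this change only loosely and gives no direction. With so little to go on, the expectation rests mainly on compound 1 at 91.1%, near the top of the scale, where a rise has little room. The expected result is a number 7.1 percentage points lower from compound 1 to compound 4 (within the scatter), a slight fall that stays within the scatter. For compound 4 the estimated value is 84%, with an expected range from 60% to 100%.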

Compound 4, percent growth inhibition at one concentration: 90.6%
Compound 4: the middle estimate sits 6.6 percentage points below what was measured, and the stated range covers the measured number.
By their numbers in this assay, from the lowest: compound 2; then compound 3; then compounds 4 and 1 (each within the scatter of the next).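

In this assay, going by these compounds alone, turning methyl into benzyl gives a number 0.5 percentage points lower from compound 1 to compound 4 (within the scatter), the first measured step at this position, so phenyl in place of hydrogen on a saturated chain carbon bound to a saturated ring carbon produces no difference beyond the scatter on the core of compound 1. Compound 1 at 91.1% and compound 4 at 90.6% both stand near the top of the scale at the one concentration tested, so this read-out may have little room to separate them. Nothing available explains why the result is so.

On these data alone, whether a longer chain in place of benzyl, or an amine or carboxylic acid on the phenyl, would keep the number this high remains open. So does whether compound 1 and compound 4 would differ at a lower concentration.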